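A few compounds are considered here, and "the series" means these few. Any claim that something is new, unique, unknown or untested is made for them only; others in the source may bear on it.

Measured compounds:
Compound 1 `O=C(Nc1ccc(Oc2ncnc3ccsc23)c(F)c1)c1nn(-c2ccc(F)c(Cl)c2)ccc1=O`, which in a functional assay on MCF7 cells (Homo sapiens) for cytotoxicity, read by MTT assay, with a stated time of 72 h (a higher number here means a weaker inhibitor, a lower number a stronger inhibitor), gives 6630 nM.
Compound 2 `O=C(Nc1ccc(Oc2ncnc3ccsc23)c(F)c1)c1nn(-c2ccc(Br)cc2)ccc1=O`, which in this assay gives 9620 nM.
Compound 3 `O=C(Nc1ccc(Oc2ncnc3ccsc23)c(F)c1)c1nn(-c2ccccc2)ccc1=O`, which in this assay gives 12400 nM.

Compound 3 carries the highest of the three numbers, but its nearest neighbour is compound 2 and its furthest is compound 1, and both gaps are within the scatter, so the three compounds cannot be ranked against each other on these data. The unmeasured compound 4 `Cc1ccc(-n2ccc(=O)c(C(=O)Nc3ccc(Oc4ncnc5ccsc45)c(F)c3)n2)cc1` differs from compound 3 by methyl in place of hydrogen on an aromatic carbon.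

Within the data shown here, the steps that bear on this change are those that vary the same aryl group on the shared core: a 1.3-fold higher number from compound 2 to compound 3 (0.11 log units; within the scatter), a 1.9-fold higher number from compound 1 to compound 3 (0.27 log units; within the scatter) and a 1.5-fold higher number from compound 1 to compound 2 (0.16 log units; within the scatter). None of them moved the number beyond the scatter, whether a halogen was added, removed or exchanged. A methyl in the same place is a change of comparable scale, so no step beyond the scatter is expected in this assay in either direction.

Compound 4 is therefore estimated to give 10000 nM, with a likely range from 4000 nM to 25000 nM, which corresponds to an expected step of a 1.2-fold lower number from compound 3 to compound 4 (0.09 log units; within the scatter).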

Compound 4, half-maximal inhibitory concentration: 23200 nM
The estimate for compound 4 lay 2.3-fold (0.37 log units) below the measured number; the range from low to high includes it.
By their numbers in this assay, from the lowest: compounds 1, 2, 3 and 4 (each within the scatter of the next, the first and the last beyond it).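

In this assay, methyl on the aromatic carbon para to a large group gives a 1.9-fold higher number from compound 3 to compound 4 (0.27 log units; within the scatter), so 4-methylphenyl cannot be told apart from phenyl at this position. Among these compounds, the new information lies in the comparisons with the halogen-bearing compounds, which give the first steps at this position to pass beyond the scatter: methyl in place of bromo gives a 2.4-fold higher number from compound 2 to compound 4 (0.38 log units; beyond the scatter), and 4-methylphenyl in place of 3-chloro-4-fluorophenyl gives a 3.5-fold higher number from compound 1 to compound 4 (0.54 log units; beyond the scatter), both modest, while compound 3, with no substituent on its phenyl, lies within the scatter of compound 1, compound 2 and compound 4 and so keeps the halogen-bearing and methyl compounds from forming two clearly separate groups. No measurement shown here accounts for these steps.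

The compounds shown leave open whether a chloro, methoxy or trifluoromethyl group at the same place would fall with bromo or with methyl. They also leave open what an amine or a carboxylic acid there would give, and whether a longer chain such as ethyl or propyl would follow methyl.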